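Series notes: aryl group on the saturated ring carbon

The compounds below may be only part of what the source reports. "The series", "measured", "known", "first", "only" and "open" are said of these compounds alone.

Three compounds of one shared core have been run in a functional assay on Ehrlich cells (Mus musculus) for cytotoxicity, tested at 50 ug/mL; on this read-out higher numbers stand for a stronger effect at the one concentration tested and lower numbers for a weaker effect. Compound 1 `COc1cc(N2C(N)=C(C#N)C(c3ccccc3O)C3=C2CC(C)(C)CC3=O)cc(OC)c1OC` gives 2%. Compound 2 `COc1cc(N2C(N)=C(C#N)C(c3ccc(OC)c4ccccc34)C3=C2CC(C)(C)CC3=O)cc(OC)c1OC` gives 40%. Compound 3 `COc1cc(N2C(N)=C(C#N)C(c3c(O)ccc4ccccc34)C3=C2CC(C)(C)CC3=O)cc(OC)c1OC` gives 15%, which places compound 3 second highest of the three numbers: it lies a number 13 percentage points higher from compound 1 to compound 3 (beyond the scatter), and a number 25 percentage points lower from compound 2 to compound 3 (beyond the scatter).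

The next compound, compound 4 `COc1cc(N2C(N)=C(C#N)C(c3ccc(C)cc3)C3=C2CC(C)(C)CC3=O)cc(OC)c1OC`, carries 4-methylphenyl in place of 2-hydroxynaphthalen-1-yl on a saturated ring carbon. Going by the values given here, no measured step matches this change directly. Among the compounds with values here, two steps touch on it. The step of a number 13 percentage points higher from compound 1 to compound 3 (beyond the scatter) shows what adding the second aromatic ring did while the hydroxyl was kept, so taking it away again points downward by a modest amount. The step of a number 25 percentage points lower from compound 2 to compound 3 (beyond the scatter) shows that the compound without a hydrogen-bond donor on the aryl group was the higher one, which points upward. The two pulls run against each other and neither has a 4-methylphenyl to anchor it, so the expected step of a number 5 percentage points lower from compound 3 to compound 4 (within the scatter) in this assay is one that need not pass beyond the scatter. For compound 4 the estimated value in this assay is 10%, with a range from 0% to 35%.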

Compound 4, a percentage reported as activity, at one concentration (the size of the read-out at that concentration, not a potency): 60%
For compound 4 the middle estimate is 50 percentage points below the measured one; the measured number lies above the stated range.
By their numbers in this assay, from the lowest: compound 1; then compound 3; then compound 2; then compound 4.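

The step of a number 45 percentage points higher from compound 3 to compound 4 (beyond the scatter) shows that this position does not need a second aromatic ring to give a high number in this assay, and the step of a number 20 percentage points higher from compound 2 to compound 4 (beyond the scatter) puts 4-methylphenyl above the methoxy-bearing naphthalene as well. Ring count alone does not order the series: the step of a number 58 percentage points higher from compound 1 to compound 4 (beyond the scatter) separates two groups that each carry one aromatic ring, so the substituents and where they sit on that ring matter here, and compound 4 is the highest of the four. No measurement at hand explains these differences.

The compounds shown do not separate the contribution of the methyl from that of losing the hydroxyl. Plain phenyl, 2-methylphenyl and 4-aminophenyl at this position would test that, and the size of the 4-substituent could be probed with 4-ethylphenyl.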